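From pentyl to ethyl on the shared core

A few compounds are considered here, and "the series" means these few. Any claim that something is new, unique, unknown or untested is made for them only; others in the source may bear on it.

Compound 1 `C=C[C@@H]1O[C@H](COCc2ccccc2)[C@@H](OCc2ccccc2)[C@H](OCc2ccccc2)[C@H]1O` gives 11800 nM
Compound 2 `CCCCC[C@@H]1O[C@H](COCc2ccccc2)[C@@H](OCc2ccccc2)[C@H](OCc2ccccc2)[C@H]1O` gives "not active" (no number reported)

In a functional assay on HL-60 cells (Homo sapiens) for antiproliferative activity, read by MTT assay (on this read-out lower numbers stand for stronger inhibition and higher numbers for weaker inhibition), compound 1 returns a number, 11800 nM, while compound 2 is reported only as "not active" (no number reported) and so has no place on the numerical scale. Compound 3 `CC[C@@H]1O[C@H](COCc2ccccc2)[C@@H](OCc2ccccc2)[C@H](OCc2ccccc2)[C@H]1O` keeps the shared core and carries the smaller chain. The structural change is hydrogen in place of propyl on a saturated chain carbon, two bonds along the chain from a saturated ring carbon and it reads in words as hydrogen in place of propyl on a saturated chain carbon, two bonds along the chain from a saturated ring carbon, or pentyl to ethyl. No measured step sizes this change. In this assay a move towards stronger inhibition is expected, from no number to a weak but measurable value, though its size cannot be stated. Compound 1 at 11800 nM is the only numerical anchor for this expectation. The estimated value for compound 3 is 15000 nM (6000 nM to 40000 nM).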

Compound 3, half-maximal inhibitory concentration: 8200 nM
The estimate for compound 3 lay 1.8-fold (0.26 log units) above the measured number; the range from low to high includes it.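

In this assay compound 3 gives 8200 nM with its ethyl chain, while compound 2 with its pentyl chain is reported only as not active, so on the shared core the shorter chain returns a number where the longer one does not. Ethyl in place of vinyl on a saturated ring carbon gives a 1.4-fold lower number from compound 1 to compound 3 (0.16 log units; within the scatter) and so leaves these two groups indistinguishable on this read-out. Nothing available explains the contrast between ethyl and pentyl.

The compounds shown leave open how the result changes along the series from ethyl to pentyl, which a propyl or butyl chain at this position would help to settle. They also leave open whether a methyl group, or a chain ending in an amine or a carboxylic acid, would return a number.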